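Swapping the Sulfonyl Substituent of a Potent Antagonist

The source may hold more compounds than are shown below. What is called first, only, known or untested is meant among the compounds shown, and "the series" means these compounds.

The measured results in an assay on CHO cells for displacement of a labelled ligand from prostaglandin D2 receptor 2 (Homo sapiens), read by scintillation counting (on this read-out lower numbers stand for stronger inhibition and higher numbers for weaker inhibition), are as follows. Compound 1, `Cc1ccc(S(=O)(=O)CCO)cc1C#Cc1cc(Cl)ccc1OCC(=O)O`, gives 19 nM. Compound 2, `O=C(O)COc1ccc(Cl)cc1C#Cc1ccncc1`, gives 601 nM. Compound 3, `O=C(O)COc1ccc(Cl)cc1C#Cc1cccnc1`, gives 117 nM.

Compound 1 stands lowest of the three, clearly separated from both of the others, with compound 3 nearer to it and compound 2 furthest away. Among the measured compounds shown here, the only step among measured compounds, a 5.1-fold lower number from compound 2 to compound 3 (0.71 log units; beyond the scatter), concerns the pyridine attached to the triple-bonded carbon, a different part of the shared core.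

The unmeasured compound 4, `Cc1ccc(S(=O)(=O)NC(C)(C)C)cc1C#Cc1cc(Cl)ccc1OCC(=O)O`, differs from compound 1 in one place: (tert-butyl)amino in place of 2-hydroxyethyl on a sulfonyl sulfur. No measured pair touches the group on the sulfonyl sulfur, so nothing shown speaks directly to this change. The expectation therefore rests on compound 1 alone, with a wide margin in both directions. For compound 4 the expected step is a 1.3-fold higher number from compound 1 to compound 4 (0.12 log units; within the scatter), which lies within the scatter. Compound 4 is expected to come out at 25 nM, with a range from 7 nM to 90 nM.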

Compound 4, inhibition constant: 5 nM
Estimate against measurement, compound 4: 5.0-fold (0.70 log units) above; measured number outside the range, below it.
By their numbers in this assay, from the lowest: compound 4; then compound 1; then compound 3; then compound 2.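

In this assay the group on the sulfonyl sulfur clearly matters: replacing 2-hydroxyethyl with (tert-butyl)amino gives a 3.8-fold lower number from compound 1 to compound 4 (0.58 log units; beyond the scatter), a modest step but the first seen at this position. The position therefore accepts a group with more heavy atoms, a branched carbon end and a nitrogen on the sulfur in place of a carbon chain ending in oxygen, and the number still falls rather than rises. Nothing shown here explains why this change lowers the number.

The change alters the atom on the sulfur and the far end of the group together, so the two contributions cannot be separated. On these data alone, it remains open how a plain amine, a methylamino group or a tert-butyl group placed directly on the sulfonyl sulfur would compare, and whether a longer chain would go further.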